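A few compounds are considered here, and "the series" means these few. Any claim that something is new, unique, unknown or untested is made for them only; others in the source may bear on it.

Compound 1, `COc1ccc(/C=C2/SC(N3CCC[C@H]3C(=O)Nc3ccc4ncnc(Nc5cccc(Cl)c5)c4c3)=NC2=O)cc1`: in a functional assay on HepG2 cells (Homo sapiens) for antiproliferative activity, read by MTT assay (on this read-out lower numbers stand for stronger inhibition and higher numbers for weaker inhibition), compound 1 gives 19000 nM.
Compound 2, `O=C1N=C(N2CCC[C@H]2C(=O)Nc2ccc3ncnc(Nc4cccc(Cl)c4)c3c2)S/C1=C/c1ccccc1Cl`: in this assay compound 2 gives 28100 nM.
Compound 3, `Cc1cccc(/C=C2/SC(N3CCC[C@H]3C(=O)Nc3ccc4ncnc(Nc5cccc(Cl)c5)c4c3)=NC2=O)n1`: in this assay compound 3 gives 4500 nM.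

Compound 3 has the lowest number of the three, and both of its steps lie beyond the scatter: a 4.2-fold lower number from compound 1 to compound 3 (0.63 log units; beyond the scatter) and a 6.2-fold lower number from compound 2 to compound 3 (0.80 log units; beyond the scatter). The two phenyl-bearing compounds, by contrast, sit within the scatter of each other, shown by a 1.5-fold higher number from compound 1 to compound 2 (0.17 log units; within the scatter).

Compound 4, `O=C1N=C(N2CCC[C@H]2C(=O)Nc2ccc3ncnc(Nc4cccc(Cl)c4)c3c2)S/C1=C/c1cccs1`, changes the same place once more: thiophen-2-yl in place of 6-methylpyridin-2-yl on a double-bonded chain carbon bound to a double-bonded ring carbon. All three measured steps bear on it, since each swaps the group on that double-bonded chain carbon, and the whole spread they cover is modest. Among the measured compounds shown here, no measured step brings in thiophen-2-yl, so the direction cannot be read off directly; what the three compounds show is that moving away from the 6-methylpyridin-2-yl of compound 3 has so far meant a higher number. A modest rise is therefore expected, with wide uncertainty. Compound 4 is expected to give about 9000 nM in this assay, within a range of 3000 nM to 27000 nM. The expected step is a 2.0-fold higher number from compound 3 to compound 4 (0.30 log units; within the scatter).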

Compound 4, half-maximal inhibitory concentration: 4120 nM
The estimate for compound 4 lay 2.2-fold (0.34 log units) above the measured number; the range from low to high includes it.
By their numbers in this assay, from the lowest: compounds 4 and 3 (each within the scatter of the next); then compounds 1 and 2 (each within the scatter of the next).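

Thiophen-2-yl is a five-membered aromatic ring with a sulfur atom, and it replaces the six-membered, nitrogen-containing 6-methylpyridin-2-yl with a 1.1-fold lower number from compound 3 to compound 4 (0.04 log units; within the scatter), so in this assay this position does not separate the two groups. The low number of compound 3 is therefore no longer a lone case tied to 6-methylpyridin-2-yl, as thiophen-2-yl also stands clear of both phenyl-bearing compounds, with a 6.8-fold lower number from compound 2 to compound 4 (0.83 log units; beyond the scatter) and a 4.6-fold lower number from compound 1 to compound 4 (0.66 log units; beyond the scatter). Among these four compounds, the two groups with a hetero atom in the aromatic ring give the lower numbers and the two substituted phenyl groups give the higher ones, with no compound going against this, although nothing at hand explains the pattern.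

Still open, from the compounds shown here alone, is whether the hetero atom itself goes with the lower numbers, a question that unsubstituted phenyl, furan-2-yl or pyridin-2-yl without its methyl group could help to settle. Also open, going by these compounds, is how a group of another kind at this position, such as a dimethylamino-bearing phenyl or a carboxylic acid-bearing phenyl, would compare in this assay.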